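Swapping a Two-Ring Group for a Substituted Phenyl

The source may hold more compounds than are shown below. What is called first, only, known or untested is meant among the compounds shown, and "the series" means these compounds.

In a functional assay on HeLa cells (Homo sapiens) for inhibition, read by CCK-8 assay, with a stated time of 48 h (a lower number here means a stronger inhibitor, a higher number a weaker inhibitor), compound 1 `COc1cc(-c2ccnc3cc(-c4ccc5c(ccn5C)c4)nn23)cc(OC)c1OC` gives 19 nM and compound 2 `COc1cc(-c2ccnc3cc(-c4cn(C)c5ccccc45)nn23)cc(OC)c1OC` gives 399 nM on the same shared core. Compound 3 `COc1cc(-c2ccnc3cc(-c4ccc5cnn(C)c5c4)nn23)cc(OC)c1OC` falls between them at 97 nM and so holds the middle place of the three. Compound 4 `COc1ccc(-c2cc3nccc(-c4cc(OC)c(OC)c(OC)c4)n3n2)cc1F` has not yet been measured. It carries 3-fluoro-4-methoxyphenyl in place of 1-methyl-1H-indazol-6-yl on an aromatic carbon and the rest of the molecule stays the same.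

Three measured steps change the group at this same place. The step of a 21-fold higher number from compound 1 to compound 2 (1.32 log units; beyond the scatter) was large, while a 5.1-fold higher number from compound 1 to compound 3 (0.71 log units; beyond the scatter) and a 4.1-fold lower number from compound 2 to compound 3 (0.61 log units; beyond the scatter) were modest. The group here can therefore shift the number in either direction. All three compounds carry two-ring groups, so none shows what a single ring does.

With that gap in mind, the expected result in this assay is a 1.5-fold higher number from compound 3 to compound 4 (0.19 log units; within the scatter) and this is a small estimated rise, not clearly beyond the scatter. For compound 4 the estimate is 150 nM with an expected range from 35 nM to 650 nM as the likely span.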

Compound 4, half-maximal inhibitory concentration: 236 nM
The estimate for compound 4 lay 1.6-fold (0.20 log units) below the measured number; the measured number falls inside the stated range.
By their numbers in this assay, from the lowest: compound 1; then compound 3; then compounds 4 and 2 (each within the scatter of the next).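

Compound 4 brings a single ring to this place, and 3-fluoro-4-methoxyphenyl gives a 2.4-fold higher number from compound 3 to compound 4 (0.39 log units; beyond the scatter) and a 12-fold higher number from compound 1 to compound 4 (1.09 log units; beyond the scatter), while a 1.7-fold lower number from compound 2 to compound 4 (0.23 log units; within the scatter) leaves it level with compound 2. A two-ring group is therefore not needed to reach the number of compound 2, but among these compounds only the 1-methyl-1H-indol-5-yl group of compound 1 gives a number as low as its own. Nothing measured here explains these differences.

The single ring carries a fluorine and a methoxy group together, so an unsubstituted phenyl would be needed to separate their shares from that of the ring itself. As far as these compounds go, how an amine or a carboxylic acid on that ring would change the number also remains open.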